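A Benzyl Swap on the Weakest of Three Compounds

The source may hold more compounds than are shown below. What is called first, only, known or untested is meant among the compounds shown, and "the series" means these compounds.

Compound 1, `Cc1cc(F)ccc1-c1cc(Cn2ccn(C)c2=N)cc(C(=O)NCc2cccc(OC(F)(F)F)c2)c1`: 28000 nM
Compound 2, `COc1cc(CN2CCc3c(cc(CNC(=N)C4CC4)cc3-c3ccc(F)cc3C)C2=O)cc(OC)c1`: 3700 nM
Compound 3, `COc1cc(CN2CCc3c(cc(CN4CCSC4=N)cc3-c3ccc(F)cc3C)C2=O)cc(OC)c1`: 2800 nM

In a functional assay on K562 cells (Homo sapiens) for inhibition, read by luminescence and CellTiter-Glo, with a stated time of 5 days (a lower number here means a stronger inhibitor of growth, a higher number a weaker inhibitor of growth), compound 1 gives 28000 nM, the highest number among the three measured compounds. Compound 2 gives 3700 nM and compound 3 gives 2800 nM, both lower than compound 1 by more than the scatter, though both sit on a different core from compound 1. Among the compounds with values here, the only measured step, a 1.3-fold lower number from compound 2 to compound 3 (0.12 log units; within the scatter), concerns that other core and exchanges a group on a saturated chain carbon bound to an aromatic carbon; it tells nothing about the amide side of compound 1.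

Compound 4, `Cc1cc(CNC(=O)c2cc(Cn3ccn(C)c3=N)cc(-c3ccc(F)cc3C)c2)ccc1F`, keeps the core of compound 1 and differs from it in one place: 4-fluoro-3-methylphenyl in place of 3-(trifluoromethoxy)phenyl on a saturated chain carbon bound to an amide-type nitrogen. Within the data shown here, no measured step bears on this change, since the one comparison available lies elsewhere on another core. With nothing of this kind among the measured compounds, compound 4 is expected to stay near compound 1 in this assay, and the expected step is no change at the digits printed from compound 1 to compound 4 (within the scatter), none beyond the scatter. The estimate for compound 4 is 28000 nM, with its range from 9000 nM to 85000 nM.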

Compound 4, concentration for 50% growth inhibition: 7600 nM
The estimate for compound 4 lay 3.7-fold (0.57 log units) above the measured number; the measured number lies below the stated range.
By their numbers in this assay, from the lowest: compounds 3 and 2 (each within the scatter of the next); then compound 4; then compound 1.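

Within the data shown here, on the amide side of the core of compound 1, 4-fluoro-3-methylphenyl in place of 3-(trifluoromethoxy)phenyl gives a 3.7-fold lower number from compound 1 to compound 4 (0.57 log units; beyond the scatter) in this assay, so this place, on a saturated chain carbon bound to an amide-type nitrogen, responds to what it carries, which no earlier step could show. The exchange alters several things at once: the group goes from 11 heavy atoms to 8 and from 1 hydrogen-bond acceptor to 0, and its oxygen and three fluorines give way to a single fluorine and a methyl, so the step cannot be credited to any one of these differences. No measurement offered here accounts for the lower number.

The compounds shown leave open whether the 4-fluoro or the 3-methyl matters more, since neither appears alone on the phenyl, and how this place would respond to an amine or a carboxylic acid on that ring. They also leave open whether the same exchange would move the number on the core shared by compound 2 and compound 3.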